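Notes on the step from compound 1 to compound 3

The source may report more compounds than this note shows. Statements on the series, on what has been measured and on what is new or still open speak of the compounds shown alone.

Measured in an ADME assay on LLC-MK2 cells (Macaca mulatta) for cytotoxicity, read by spectrophotometry and crystal violet staining, with a stated time of 4 days; on this read-out higher numbers stand for lower toxicity in this test and lower numbers for higher toxicity in this test:
- compound 1 `CC(C)n1ncc2c(C(=O)Nc3c(F)cccc3F)cc(-c3cccs3)nc21` gives > 200000 nM (a limit)
- compound 2 `CC(C)n1ncc2c(NC(=O)c3ccc(F)cc3)cc(-c3cccs3)nc21` gives 50000 nM

Compound 1 stands only at a limit, not at a number. Compound 3 `CC(C)n1ncc2c(C(=O)N3CCc4cccnc43)cc(-c3cccs3)nc21` is not yet measured, and against compound 1 it carries a group of 9 heavy atoms (7 carbon, 2 nitrogen; one five-membered non-aromatic ring with 1 hetero atom, one six-membered aromatic ring with 1 hetero atom) in place of a group of 9 heavy atoms (6 carbon, 1 nitrogen, 2 fluorine; one six-membered aromatic ring of carbon only), on a carbonyl carbon. Within the data shown here, no measured step covers such a change. Among the measured compounds shown here, a modest fall in this assay is expected, resting only on compound 2 with 50000 nM as the one true number. The expected size is an at least 1.8-fold lower number from compound 1 to compound 3 (0.25 log units; that floor lies within the scatter). For compound 3 the estimated value is 110000 nM, with an expected range from 40000 nM to 250000 nM.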

Compound 3, half-maximal cytotoxic concentration: 50000 nM
Beside the measured number, compound 3's estimate is 2.2-fold (0.34 log units) above it; low and high end bracket the measured number.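

At the carbonyl carbon, putting the group with a five-membered non-aromatic ring and a six-membered aromatic ring in place of (2,6-difluorophenyl)amino gives an at least 4.0-fold lower number from compound 1 to compound 3 (0.60 log units; beyond the scatter) in this assay. This position therefore bears on the read-out, and the change lies beyond the scatter. Compound 1 stands at a limit, not a number, so the step gives only a floor: the limit of > 200000 nM in this assay, at which 1 of the 3 values shown sits.

From the compounds shown here alone, the change swaps the ring system and removes the hydrogen-bond donor together, and which of these carries the step stays open. Going by these compounds, how a dimethylamino or morpholine group on the carbonyl carbon would read also stays open.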